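The source may report more compounds than this note shows. Statements on the series, on what has been measured and on what is new or still open speak of the compounds shown alone.

Working notes on a short series sharing one core. Compound 2 `COc1ccc(-c2nc3cc(C(F)(F)F)ccc3[nH]2)cc1` gives 2000 nM in an ADME assay on MT4 cells (Homo sapiens) for cytotoxicity, read by MTT assay, with a stated time of 96 h (on this read-out lower numbers stand for higher toxicity in this test and higher numbers for lower toxicity in this test), the lowest of the two plain numbers recorded. Its nearest neighbour is compound 3 `Fc1ccc(-c2nc3cc(C(F)(F)F)ccc3[nH]2)cc1`, which gives 22000 nM. Between them lies an 11-fold higher number from compound 2 to compound 3 (1.04 log units; beyond the scatter). Compound 1 `COc1ccc(-c2nc3cc(C(F)(F)F)ccc3[nH]2)c(OC)c1` gives > 100000 nM, a limit of the assay rather than a number, namely (the limit of > 100000 nM in this assay, at which 1 of the 3 values shown sits). Between compound 1 and compound 2 lies an at least 50-fold lower number from compound 1 to compound 2 (1.69 log units; beyond the scatter). Compound 4 `COc1ccc(-c2nc3cc(C(F)(F)F)ccc3[nH]2)c(N)c1` is unmeasured and differs from compound 2 by amino in place of hydrogen on an aromatic carbon. The step bearing most on it is an at least 50-fold lower number from compound 1 to compound 2 (1.69 log units; beyond the scatter), since it removes a group from the same aromatic carbon that compound 4 fills; read in reverse, filling that carbon went with a large rise. A large upward step in this assay is therefore expected, a 10-fold higher number from compound 2 to compound 4 (1.00 log units; beyond the scatter). Compound 4 is expected to give 20000 nM, within 4000 nM to 100000 nM.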

Compound 4, half-maximal cytotoxic concentration: 5000 nM
For compound 4 the middle estimate is 4.0-fold (0.60 log units) above the measured one; measured number inside the range.
By their numbers in this assay, from the lowest: compound 2; then compound 4; then compound 3. At a limit, above all of these: compound 1.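

In this assay, filling this aromatic carbon with amino gives a 2.5-fold higher number from compound 2 to compound 4 (0.40 log units; beyond the scatter), so a rise on filling it now holds for a second group, though this step is modest. The group entering matters at this carbon, with an at least 20-fold lower number from compound 1 to compound 4 (1.30 log units; beyond the scatter). Compound 1 stands at a limit of the assay and not at a number, so the full size of that step stays unknown: the limit of > 100000 nM in this assay, at which 1 of the 4 values shown sits.

Open, on these data alone, is where a hydroxyl group or a dimethylamino group on this carbon would fall in this order. Also open, as far as these compounds go, is whether amino would give a similar rise without the methoxy group that compound 4 carries.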